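The source may hold more compounds than are shown below. What is called first, only, known or untested is meant among the compounds shown, and "the series" means these compounds.

Compound 3, `COc1ccc(S(=O)(=O)c2cnc3ccc(Cl)cc3c2N2CCC(C)CC2)cc1Cl`, stands lowest of the three measured compounds in an assay on isolated protein for displacement of a labelled ligand from metabotropic glutamate receptor 5 (Homo sapiens), with a stated time of 60 min, tested at 1 uM; on this read-out lower numbers stand for less inhibition and higher numbers for more inhibition at the one concentration tested (going by the name of the read-out): compound 3 gives 46%, while compound 1, `CC1CCN(c2c(S(=O)(=O)c3cccc(F)c3)cnc3ccc(Cl)cc23)CC1`, gives 58% and compound 2, `CC1CCN(c2c(S(=O)(=O)c3ccc(F)cc3)cnc3ccc(Cl)cc23)CC1`, gives 89%. All three differ only in the group on the sulfonyl sulfur, and the steps there are sizeable: a number 31 percentage points higher from compound 1 to compound 2 (beyond the scatter), a number 12 percentage points lower from compound 1 to compound 3 (beyond the scatter) and a number 43 percentage points lower from compound 2 to compound 3 (beyond the scatter). Compound 4, `Cc1cc(C)cc(S(=O)(=O)c2cnc3ccc(Cl)cc3c2N2CCC(C)CC2)c1`, changes the same place: 3,5-dimethylphenyl in place of 3-chloro-4-methoxyphenyl on a sulfonyl sulfur. Among the compounds with values here, no measured step involves the 3,5-dimethylphenyl group, so the bearing of the known steps is indirect; they show only that changes at this position have moved the read-out in both directions, and that compound 3 holds the lowest number so far. On that basis compound 4 is expected to land between the measured extremes, with an upward step of a number 14 percentage points higher from compound 3 to compound 4 (beyond the scatter) considered the most likely outcome, though with wide uncertainty. Compound 4 is therefore estimated at 60%, in a range from 35% to 85%.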

Compound 4, a percentage reported as inhibition, at one concentration (the size of the read-out at that concentration, not a potency): 49%
For compound 4 the middle estimate is 11 percentage points above the measured one; low and high end bracket the measured number.
By their numbers in this assay, from the lowest: compounds 3, 4 and 1 (each within the scatter of the next, the first and the last beyond it); then compound 2.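

In this assay, the 3,5-dimethylphenyl group on the sulfonyl sulfur, which holds only carbon, cannot be told from either of two quite different groups: the change gives a number 3 percentage points higher from compound 3 to compound 4 (within the scatter) and also a number 9 percentage points lower from compound 1 to compound 4 (within the scatter) in this comparison. The 4-fluorophenyl group of compound 2 stays apart from it, with a number 40 percentage points lower from compound 2 to compound 4 (beyond the scatter) as the step, so among the four groups shown it alone gives a number far from the others. Nothing at hand explains why this one group stands apart.

As far as these compounds go, whether that high number is special to fluorine or would also appear with a 4-chlorophenyl, 4-methylphenyl or plain phenyl group on the sulfonyl sulfur remains open. So does the response to a group without an aromatic ring there, such as cyclohexyl or a short alkyl chain.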